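Swapping the aryl group on the shared core of compound 1

This account rests on a few compounds, and the source may have more. Where it says the series, first, only, none or still open, it means among the compounds named here.

Measured compounds:
- compound 1 `O=C(NO)c1ccc(NCc2nc(-c3cccnc3)nn2-c2ccccc2)cc1`: 57.7%
- compound 2 `Nc1ccccc1NC(=O)c1ccc(NCc2nc(-c3ccccc3)nn2-c2ccccc2)cc1`: 5%
- compound 3 `NC(=O)c1ccc(NCc2nc(-c3ccccc3)nn2-c2ccccc2)cc1`: -4.4%

In an assay on Sf9 cells for inhibition of protein deacetylase HDAC6 (Homo sapiens), read by fluorescence, with a stated time of 40 min, tested at 100 nM (a lower number here means less inhibition, a higher number more inhibition at the concentration tested (going by the name of the read-out)), compound 1 gives 57.7%, the highest of the three numbers. Compound 2 gives 5% and compound 3 gives -4.4%, both beyond the scatter below compound 1. Within the data shown here, the only single-site step among the measured compounds is a number 9.4 percentage points lower from compound 2 to compound 3 (within the scatter), and it lies within the scatter. Both compound 2 and compound 3 differ from compound 1 in more than one place, so their numbers say nothing direct about the change now considered.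

Compound 4 `Cc1ccsc1-c1nc(CNc2ccc(C(=O)NO)cc2)n(-c2ccccc2)n1` differs from compound 1 in one place: 3-methylthiophen-2-yl in place of pyridin-3-yl on an aromatic carbon. Among the measured compounds shown here, no measured step touches this position, so there is no basis for expecting a shift beyond the scatter in either direction. Compound 4 is therefore expected to give about 55% in this assay, with a range from 35% to 75%, an expected step of a number 2.7 percentage points lower from compound 1 to compound 4 (within the scatter).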

Compound 4, a percentage reported as inhibition, at one concentration (the size of the read-out at that concentration, not a potency): 72.1%
The estimate for compound 4 lay 17.1 percentage points below the measured number, and the stated range covers the measured number.
By their numbers in this assay, from the lowest: compounds 3 and 2 (each within the scatter of the next); then compound 1; then compound 4.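

This position, an aromatic carbon between two ring nitrogen atoms, is not a silent one: in this assay, 3-methylthiophen-2-yl in place of pyridin-3-yl gives a number 14.4 percentage points higher from compound 1 to compound 4 (beyond the scatter). Among these compounds, no earlier step touched this place, so this is the first sign that the group here can change the inhibition seen at the concentration tested, and that a five-membered aromatic ring with sulfur can take the place of a six-membered one with nitrogen without loss. Nothing available explains the rise.

Ring size, hetero atom and methyl group all change in this single swap, so the compounds shown cannot say which of them matters. As far as these compounds go, how a thiophen-2-yl group without the methyl, or a non-aromatic amine such as morpholin-4-yl, would behave at this place remains open.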